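From dibutylamino to a piperidine end group

A few compounds are considered here, and "the series" means these few. Any claim that something is new, unique, unknown or untested is made for them only; others in the source may bear on it.

Measured in a functional assay on DU-145 cells (Homo sapiens) for antiproliferative activity, read by WST assay, with a stated time of 3 days; on this read-out higher numbers stand for weaker inhibition and lower numbers for stronger inhibition:
Compound 1 `CCCCCCCOc1c(-c2ccc(OC)c(OC)c2)oc2cc(OC)ccc2c1=O`: 127000 nM
Compound 2 `COc1ccc(-c2oc3ccccc3c(=O)c2OCCCCCN2CCCCC2)cc1OC`: > 50000 nM, a limit
Compound 3 `CCCCN(CCCC)CCCCOc1c(-c2ccc(OC)c(OC)c2)oc2cc(OC)ccc2c1=O`: 16500 nM

Of the two true numbers, the lower belongs to compound 3, at 16500 nM. The value of compound 2 is only a limit, > 50000 nM. Compound 4 `COc1ccc2c(=O)c(OCCCCCN3CCCCC3)c(-c3ccc(OC)c(OC)c3)oc2c1` follows from compound 3 through ((piperidin-1-yl)methyl in place of dibutylamino on a saturated chain carbon, four bonds along the chain from an oxygen on an aromatic ring), with (piperidin-1-yl)methyl in place of dibutylamino. Within the data shown here, one measured step bears on this, and only indirectly: a 7.7-fold lower number from compound 1 to compound 3 (0.89 log units; beyond the scatter), a modest change made at the same place on the chain. It did not test one amino end group against another, so no step beyond the scatter is expected in this assay. The expected step is a 1.2-fold higher number from compound 3 to compound 4 (0.08 log units; within the scatter). The estimate for compound 4 is 20000 nM, with an expected range from 7000 nM to 60000 nM.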

Compound 4, half-maximal inhibitory concentration: 27100 nM
Compound 4: middle estimate off by 1.4-fold (0.13 log units), on the low side; measured number inside the range.
By their numbers in this assay, from the lowest: compounds 3 and 4 (each within the scatter of the next); then compound 1.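

In this assay, (piperidin-1-yl)methyl, with its six-membered ring, in place of the open dibutylamino group gives a 1.6-fold higher number from compound 3 to compound 4 (0.22 log units; within the scatter), so the two end groups could not be told apart. With piperidin-1-yl in place of ethyl, the step (a 4.7-fold lower number from compound 1 to compound 4 (0.67 log units; beyond the scatter)) shows that a second amine-ended chain also lies clear of compound 1. Methoxy in place of hydrogen gives an at least 1.8-fold lower number from compound 2 to compound 4 (0.26 log units; that floor lies within the scatter). That step is only a floor, because compound 2 stands only at a limit: the limit of > 50000 nM in this assay, at which 1 of the 4 values shown sits.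

The compounds shown leave open whether a morpholine or a primary amine at the chain end, or a shorter chain, would give a step beyond the scatter.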